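Three thiazolidinediones measured, a fourth awaiting a number

A few compounds are considered here, and "the series" means these few. Any claim that something is new, unique, unknown or untested is made for them only; others in the source may bear on it.

Three compounds share a core and were tested in a functional assay on the whole organism (plasma, strain Wistar) with Rattus norvegicus as the target, with a stated time of 15 days, at a dose of 10 mg/kg by the oral route; a higher number here means a stronger effect of the compound at the dose given, a lower number a weaker effect. Compound 1 `Cc1nc(COc2ccc(/C=C3\SC(=O)NC3=O)cc2)cs1` gives 10.6% in this assay. Compound 2 `O=C1NC(=O)/C(=C/c2ccc(OCCSc3nnc(Cc4ccccc4)[nH]3)cc2)S1` gives 19.4% in this assay. Compound 3 `O=C1NC(=O)/C(=C/c2ccc(OCCSc3nnc(Cc4ccccc4)o3)cc2)S1` gives 16.8% in this assay. Among the measured compounds shown here, the three numbers all lie within the usual scatter of one another, so compound 3 cannot be set apart from compound 2 or from compound 1 on these readings, and no pair of them differs in a way that counts as a step.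

Compound 4 `O=C1NC(=O)/C(=C/c2ccc(OCCSc3nnc(-c4ccncc4)o3)cc2)S1` has not yet been measured in this assay. It differs from compound 3 in one place: pyridin-4-yl in place of benzyl on an aromatic carbon. For the measured compounds named here, nothing among the measured compounds shows what such an exchange does in this assay, so no direction can be drawn from them.

Compound 4 is therefore expected to stay near compound 3, with a step of a number 0.8 percentage points lower from compound 3 to compound 4 (within the scatter) that is estimated not to exceed the scatter. The value expected for compound 4 in this assay is 16%, with a range from 6% to 28%.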

Compound 4, a percentage reported as activity, at one dose (the size of the read-out at that dose, not a potency): 32.6%
Compound 4: the middle estimate sits 16.6 percentage points below what was measured, and the stated range ends below it.
By their numbers in this assay, from the lowest: compounds 1, 3 and 2 (each within the scatter of the next); then compound 4.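

In this assay the carbon of the five-membered aromatic ring that bears this group proves sensitive to what it carries: pyridin-4-yl in place of benzyl gives a number 15.8 percentage points higher from compound 3 to compound 4 (beyond the scatter) and is the first step beyond the scatter among the compounds shown. The earlier compounds shown here, all within the scatter of one another, offered no sign that a change at this place could move the read-out. Nothing at hand bears on why the number rises here.

The exchange both brings in a ring nitrogen and removes the carbon link of benzyl, and this single step cannot tell the two apart; a phenyl or a pyridin-4-ylmethyl group at the same place would separate them. From the compounds shown here alone, whether the same exchange would act alike on compound 2 also stays open.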